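A Chloro Group Gives Way to Hydrogen

The source may report more compounds than this note shows. Statements on the series, on what has been measured and on what is new or still open speak of the compounds shown alone.

Of the compounds shown here, two have values so far in a functional assay on U-87MG ATCC cells (Homo sapiens) for cytotoxicity, read by MTT assay, with a stated time of 48 h; on this read-out lower numbers stand for stronger inhibition and higher numbers for weaker inhibition. Compound 1 `CC(=NNC(=S)Nc1ccccc1)c1ccccn1` gives 1.4 nM on this read-out, and compound 2 `C/C(=N\NC(=S)Nc1ccccc1Cl)c1ccccn1` gives 2.6 nM on the same read-out. These two values lie within the scatter of each other, so no order can be read between them, and compound 2 stands alongside compound 1 on the present numbers.

The next compound, compound 3 `C/C(=N\NC(=S)Nc1ccccc1)c1ccccn1`, still awaits measurement in this assay. Passing from compound 2 to compound 3, hydrogen takes the place of chloro on an aromatic carbon (hydrogen in place of chloro on an aromatic carbon), a carbon of a six-membered aromatic ring of carbon only, ortho to a large group. Among the measured compounds shown here, no measured pair here differs in one place, so the size of this step has no direct precedent. For the measured compounds named here, the only guide is that compound 1 at 1.4 nM and compound 2 at 2.6 nM sit within the scatter of each other, so no change beyond the scatter is expected. The expected move is a 1.6-fold lower number from compound 2 to compound 3 (0.21 log units; within the scatter) and would stay inside that scatter. For compound 3 the estimated value is 1.6 nM with an expected range from 0.7 nM to 3.5 nM for this estimate.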

Compound 3, half-maximal inhibitory concentration: 1.4 nM
Beside the measured number, compound 3's estimate is 1.1-fold (0.06 log units) above it; the measured number falls inside the stated range.
By their numbers in this assay, from the lowest: compounds 1, 3 and 2 (each within the scatter of the next).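

In this assay, among the compounds shown here, putting hydrogen in place of chloro on an aromatic carbon, ortho to a large group, gives the first direct reading at this position: the result is a 1.9-fold lower number from compound 2 to compound 3 (0.27 log units; within the scatter), so on this one pair the chloro group makes no difference that can be told from the scatter. The second pair gives no change at the digits printed from compound 1 to compound 3 (within the scatter), which means that the double bond drawn as E in compound 3 and without a configuration in compound 1 adds no readable difference on these values. Compounds 1 and 3 have the same atoms and bonds, so what separates them is only a matter of how the structures are drawn: the fact that one of compounds 1 and 3 is drawn with a defined configuration and the other without, at the place where they differ.

The compounds shown leave open whether this position would respond to a group other than chloro or hydrogen, such as a methoxy group, an amine or a carboxylic acid, and whether chloro elsewhere on the same ring would read as it does here. They also leave open how the Z form of the double bond would read on this assay.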